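This account rests on a few compounds, and the source may have more. Where it says the series, first, only, none or still open, it means among the compounds named here.

Measured compounds:
compound 1 `Cc1ccc(S(=O)(=O)/N=C(/CCNC2=CC(=O)c3ccccc3C2=O)Nc2cccc(C)c2)cc1` — 10200 nM
compound 2 `COc1ccc(N/C(CCNC2=CC(=O)c3ccccc3C2=O)=N\S(=O)(=O)c2ccc(C)cc2)c(OC)c1` — 67300 nM
compound 3 `Cc1ccc(S(=O)(=O)/N=C(/CCNC2=CC(=O)c3ccccc3C2=O)Nc2ccc(Cl)cc2Cl)cc1` — 18600 nM

In a functional assay on DU-145 cells (Homo sapiens) for cytotoxicity, read by MTT assay, with a stated time of 48 h (a lower number here means a stronger inhibitor, a higher number a weaker inhibitor), compound 1 gives the lowest of these three numbers; its nearest neighbour is compound 3, with a step of a 1.8-fold higher number from compound 1 to compound 3 (0.26 log units; within the scatter), and the furthest is compound 2, with a 6.6-fold higher number from compound 1 to compound 2 (0.82 log units; beyond the scatter). Compound 4 `COc1cc(N/C(CCNC2=CC(=O)c3ccccc3C2=O)=N\S(=O)(=O)c2ccc(C)cc2)cc(OC)c1OC` differs from compound 1 in one place: 3,4,5-trimethoxyphenyl in place of 3-methylphenyl on an amine nitrogen. Among the compounds with values here, two measured steps bear on this change: the move to 2,4-dimethoxyphenyl, which also brings in methoxy groups, gave a 6.6-fold higher number from compound 1 to compound 2 (0.82 log units; beyond the scatter), while the move to 2,4-dichlorophenyl gave a 1.8-fold higher number from compound 1 to compound 3 (0.26 log units; within the scatter). The methoxy-bearing step was clearly the larger of the two. Compound 4 is therefore expected to show a higher number, an estimated step of a 3.9-fold higher number from compound 1 to compound 4 (0.59 log units; beyond the scatter). Compound 4 is estimated at 40000 nM, with a range from 15000 nM to 110000 nM.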

Compound 4, half-maximal inhibitory concentration: 9330 nM
Estimate against measurement, compound 4: 4.3-fold (0.63 log units) above; measured number outside the range, below it.
By their numbers in this assay, from the lowest: compounds 4, 1 and 3 (each within the scatter of the next); then compound 2.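

The step to 3,4,5-trimethoxyphenyl on the amine nitrogen is a 1.1-fold lower number from compound 1 to compound 4 (0.04 log units; within the scatter), and replacing 2,4-dichlorophenyl with it is a 2.0-fold lower number from compound 3 to compound 4 (0.30 log units; within the scatter), so methoxy groups at this position do not by themselves raise the number. The two methoxy-bearing groups are not alike, since replacing 2,4-dimethoxyphenyl with 3,4,5-trimethoxyphenyl gives a 7.2-fold lower number from compound 2 to compound 4 (0.86 log units; beyond the scatter). Nothing measured here explains why these two groups differ.

Still open, going by these compounds, is how a phenyl group carrying a single methoxy group would compare. So is the effect of placing an amine or a carboxylic acid on this phenyl group.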